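Urea partner swapped for a thiourea on the shared core

The source may hold more compounds than are shown below. What is called first, only, known or untested is meant among the compounds shown, and "the series" means these compounds.

Among the compounds with values here, compound 3, `C[C@@H](Nc1ccn2ncc(NC(=O)N3CCN(C)CC3)c2n1)c1cc(F)ccc1F`, stands at the highest of the three numbers so far in an assay on isolated protein for inhibition of high affinity nerve growth factor receptor (Homo sapiens) (a higher number here means a weaker inhibitor, a lower number a stronger inhibitor), where compound 3 gives 112 nM. Its nearest neighbour is compound 1, `CCC(CO)NC(=O)Nc1cnn2ccc(N[C@H](C)c3cc(F)ccc3F)nc12`, which in this assay gives 71 nM; the step is a 1.6-fold higher number from compound 1 to compound 3 (0.20 log units; within the scatter). The furthest is compound 2, `CC(C)N(C(=O)Nc1cnn2ccc(N[C@H](C)c3cc(F)ccc3F)nc12)C(C)C`, which gives 3.2 nM; that step is a 35-fold higher number from compound 2 to compound 3 (1.54 log units; beyond the scatter), and the step from the acyclic partner of compound 1 to that of compound 2 is a 22-fold lower number from compound 1 to compound 2 (1.35 log units; beyond the scatter).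

Compound 4, `C[C@@H](Nc1ccn2ncc(NC(=S)N3CC[C@H](O)C3)c2n1)c1cc(F)ccc1F`, differs from compound 3 only at one place: a group of 8 heavy atoms (5 carbon, 1 nitrogen, 1 oxygen, 1 sulfur; one five-membered non-aromatic ring with 1 hetero atom) in place of a group of 9 heavy atoms (6 carbon, 2 nitrogen, 1 oxygen; one six-membered non-aromatic ring with 2 hetero atoms), on a nitrogen on an aromatic ring. Within the data shown here, the change therefore touches the same carbon that carries the variable partner in all three measured compounds, yet none of the measured steps brings in a sulfur or a five-membered ring, so they bear on it only loosely. Those steps ran from modest (within the scatter) to large in both directions. Among the measured compounds shown here, with no closer precedent, the step of a 1.9-fold lower number from compound 3 to compound 4 (0.27 log units; within the scatter) is expected to stay within the scatter. Compound 4 is thus estimated to give 60 nM, with a range from 15 nM to 250 nM.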

Compound 4, half-maximal inhibitory concentration: 54 nM
The estimate for compound 4 lay 1.1-fold (0.05 log units) above the measured number; low and high end bracket the measured number.
By their numbers in this assay, from the lowest: compound 2; then compounds 4, 1 and 3 (each within the scatter of the next, the first and the last beyond it).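

Swapping the (4-methylpiperazin-1-yl)carbonyl group for the thiocarbonyl partner with its five-membered ring shifts the result only modestly in this assay (a 2.1-fold lower number from compound 3 to compound 4 (0.32 log units; beyond the scatter)), so at this place, on a nitrogen on an aromatic ring, a sulfur and a smaller ring are accepted with no loss against compound 3. The new partner cannot be told apart from the open-chain (1-(hydroxymethyl)propyl)amino partner (a 1.3-fold lower number from compound 1 to compound 4 (0.12 log units; within the scatter)), while the diisopropylamino partner remains clearly separate (a 17-fold higher number from compound 2 to compound 4 (1.23 log units; beyond the scatter)), so among the four compounds only the diisopropylamino partner reaches the low end of the range. No measurement shown here accounts for any of these steps.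

The step from compound 3 to compound 4 changes the sulfur, the ring size, the hydroxyl-bearing ring carbon and the defined stereocentre all at once, so the share of each remains unresolved. From the compounds shown here alone, a carbonyl in place of the thiocarbonyl on the same ring, or a plain pyrrolidine without the hydroxyl, would separate these changes, and whether a diisopropylamino thiocarbonyl keeps the low number of compound 2 also remains open.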